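Methyl to Chloro on the Aromatic Ring: Expected Cell Tolerance

A few compounds are considered here, and "the series" means these few. Any claim that something is new, unique, unknown or untested is made for them only; others in the source may bear on it.

Measured so far in an ADME assay on MT4 cells (Homo sapiens) for cytotoxicity, read by MTT assay; a lower number here means that less compound is tolerated, a higher number that more compound is tolerated:
- compound 1, `Cc1cccc(NC(=S)OCCc2ccccn2)c1`, gives > 100000 nM, a limit of the assay rather than a number.
- compound 2, `S=C(Nc1cccc(Cl)c1)OCCc1ccccn1`, gives 47000 nM.
- compound 3, `Cc1ccc(NC(=S)OCCc2ccncc2)cc1`, gives > 100000 nM, again a limit of the assay.

Compound 1 and compound 2 share one core and differ in a single place: chloro in place of methyl on an aromatic carbon. This change produced an at least 2.1-fold lower number from compound 1 to compound 2 (0.32 log units; beyond the scatter). Because (the limit of > 100000 nM in this assay, at which 2 of the 3 values shown sit), the true size of that step is not fully known; it is a lower bound.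

Compound 3 has the same atoms as compound 1, joined differently, and the difference between the two cores is not broken down here. Compound 4, `S=C(Nc1ccc(Cl)cc1)OCCc1ccncc1`, has not yet been measured in this assay. It relates to compound 3 by chloro in place of methyl on an aromatic carbon. Going by the values given here, this is the same kind of change as the one from compound 1 to compound 2, though the two places are not identical: in the first pair the group sits meta to a large group, in the second pair para to a large group.

On the strength of the earlier step, compound 4 is expected to show an at least 1.6-fold lower number from compound 3 to compound 4 (0.22 log units; that floor lies within the scatter) in this assay, resting on an at least 2.1-fold lower number from compound 1 to compound 2 (0.32 log units; beyond the scatter). Compound 4 is therefore estimated at 60000 nM, with a range from 25000 nM to 150000 nM, keeping in mind that compound 3 provides only a limit and the assay may again report only a limit.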

Compound 4, half-maximal cytotoxic concentration: 70000 nM
Beside the measured number, compound 4's estimate is 1.2-fold (0.07 log units) below it; low and high end bracket the measured number.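

In this assay, putting chloro in place of methyl on an aromatic carbon, here para to a large group, gave an at least 1.4-fold lower number from compound 3 to compound 4 (0.15 log units; that floor lies within the scatter), so the change again comes with a lower number on this second core, though the floor of this step does not by itself clear the usual scatter. Compound 3 gives > 100000 nM, which is a limit of the assay and not a number, so this step shows only the least it could be and not its true size. The result therefore supports carrying the direction of the change from one core to the other in these two pairs, but it does not show that the change has the same size on both cores: the same change on two cores in this assay, an at least 2.1-fold lower number (0.32 log units; beyond the scatter) from compound 1 to compound 2 and an at least 1.4-fold lower number (0.15 log units; that floor lies within the scatter) from compound 3 to compound 4; the limit leaves it open whether they differ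

Going by these compounds, it remains open whether a methyl compound with a value inside the range of the assay would give both steps a true size. On these data alone, it also remains open whether other groups on that aromatic carbon, such as a fluoro, a trifluoromethyl or an amine, would shift the number as chloro does on these two cores.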